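Methylsulfonyl replaces the chlorophenyl amide on compound 1

A few compounds are considered here, and "the series" means these few. Any claim that something is new, unique, unknown or untested is made for them only; others in the source may bear on it.

Compound 1 `O=C(Nc1ccc(O)c2c(=O)cc(-c3ccccc3Cl)oc12)c1ccc(Cl)cc1`: 4600 nM
Compound 2 `O=C(Nc1c(O)cc(O)c2c(=O)cc(-c3ccccc3Cl)oc12)c1ccc(Cl)cc1`: 13000 nM
Compound 3 `C[C@@H](NC(=O)OC(C)(C)C)C(=O)Nc1ccc(O)c2c(=O)cc(-c3ccccc3Cl)oc12`: 5500 nM

In a functional assay on MCF7 cells (Homo sapiens) for antiproliferative activity (on this read-out higher numbers stand for weaker inhibition and lower numbers for stronger inhibition), compound 1 gives 4600 nM, the lowest of the three numbers. The nearest number lies one step away: a 1.2-fold higher number from compound 1 to compound 3 (0.08 log units; within the scatter). The furthest also lies one step away: a 2.8-fold higher number from compound 1 to compound 2 (0.45 log units; beyond the scatter).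

Compound 4 `CS(=O)(=O)Nc1ccc(O)c2c(=O)cc(-c3ccccc3Cl)oc12` has not yet been measured. It differs from compound 1 in one place: methylsulfonyl in place of (4-chlorophenyl)carbonyl on a nitrogen on an aromatic ring. For the measured compounds named here, of the measured steps, only the one to compound 3 changes the group on this same nitrogen, and there a 1.2-fold higher number from compound 1 to compound 3 (0.08 log units; within the scatter) stayed within the scatter although the group that entered was quite different from the one that left. The step to compound 2 alters another part of the core and does not bear directly on this change. On that basis the expected step in this assay is small: a 1.4-fold higher number from compound 1 to compound 4 (0.15 log units; within the scatter), possibly a modest rise, but nothing clearly beyond the scatter is anticipated. Compound 4 is therefore estimated at 6500 nM, with a range from 2500 nM to 20000 nM.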

Compound 4, half-maximal inhibitory concentration: 25000 nM
Beside the measured number, compound 4's estimate is 3.8-fold (0.59 log units) below it; measured number outside the range, above it.
By their numbers in this assay, from the lowest: compounds 1 and 3 (each within the scatter of the next); then compounds 2 and 4 (each within the scatter of the next).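

In this assay, this nitrogen on the aromatic ring proves less tolerant than the earlier step suggested: methylsulfonyl in place of (4-chlorophenyl)carbonyl gives a 5.4-fold higher number from compound 1 to compound 4 (0.74 log units; beyond the scatter), beyond the scatter, whereas 1-((tert-butoxycarbonyl)amino)ethyl in place of 4-chlorophenyl on the carbonyl carbon gave only a 1.2-fold higher number from compound 1 to compound 3 (0.08 log units; within the scatter), within it. The earlier tolerance therefore covers two groups that both keep the carbonyl on this nitrogen, and it does not extend to methylsulfonyl. No measurement at hand explains this weaker inhibition.

The compounds shown leave open whether the change follows from losing the carbonyl or from losing the 4-chlorophenyl ring, a question that an acetyl group or a 4-chlorophenylsulfonyl group on the same nitrogen could separate. From the compounds shown here alone, how the free amine would behave at this position also remains open.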